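The source may report more compounds than this note shows. Statements on the series, on what has been measured and on what is new or still open speak of the compounds shown alone.

Measured in a functional assay on HL-60 cells (Homo sapiens); on this read-out higher numbers stand for an effect only at larger amounts of compound and lower numbers for an effect already at smaller amounts:
- compound 1 `COc1cc(/C=C\c2ccc(O[Si](C)(C)C(C)(C)C)cc2)cc(OC)c1`: limit of > 200000 nM
- compound 2 `COc1cc(/C=C/c2ccc(O[Si](C)(C)C(C)(C)C)cc2)cc(OC)c1`: limit of > 200000 nM

Compound 2 has no number on this scale and sits at the limit of > 200000 nM in this assay, at which 2 of the 2 values shown sit. The step to compound 3 `COc1cc(/C=C/c2ccc(N)cc2)cc(OC)c1` is one nitrogen atom in place of a group of 8 heavy atoms (6 carbon, 1 oxygen, 1 silicon; no ring), on an aromatic carbon. Among the compounds with values here, the only measured step is a step that the two limits leave unreadable from compound 1 to compound 2. Within the data shown here, it concerns (the fact that compounds 1 and 2 differ only in the configuration as drawn), so no measured step gives a size for this change of group. Compound 2 gives only the limit > 200000 nM, which leaves room for movement in one direction only. In this assay, the expected step is an at least 6.6-fold lower number from compound 2 to compound 3 (0.82 log units; beyond the scatter), towards lower numbers, and its size is only loosely estimated. For compound 3 the estimate is 30000 nM, with an expected range of 5000 nM to 200000 nM.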

Compound 3, concentration for half-maximal activity: 15000 nM
Estimate against measurement, compound 3: 2.0-fold (0.30 log units) above, within the range that was stated.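

In this assay, within the data shown here, amino in place of the group of 8 heavy atoms on the aromatic carbon is an at least 13-fold lower number from compound 2 to compound 3 (1.12 log units; beyond the scatter), the only readable step here and one beyond the scatter. For compound 2, the value > 200000 nM is a limit of the assay, not a number. Among these compounds, the step between compound 1 and compound 2 cannot be read, so compound 3 provides the only number.

Still open, going by these compounds, is whether amino itself or the loss of the larger group drives the step. A hydroxyl or a dimethylamino group on the same aromatic carbon would separate the two.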